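The source may report more compounds than this note shows. Statements on the series, on what has been measured and on what is new or still open speak of the compounds shown alone.

Compound 1, `CCCCc1nc(N)c2nc(O)n(Cc3ccccc3)c2n1`: 0.03 uM
Compound 2, `Nc1ncnc2c1nc(O)n2-c1ccccc1`: > 10 uM
Compound 3, `COc1ccc(Cn2c(O)nc3c(N)ncnc32)cc1`: 10 uM

Of the compounds shown here, three built on one shared core have been tested in a functional assay (spleen, spleen) for activation, with Mus musculus as the target; on this read-out lower numbers stand for an effect already at smaller amounts and higher numbers for an effect only at larger amounts of compound. Compound 1 gives 0.03 uM, the lowest of the two numbers shown. Compound 3 gives 10 uM, a far higher number, well beyond the scatter. For compound 2 the assay reports only a limit, > 10 uM, as noted in the limit of > 10 uM in this assay, at which 1 of the 3 values shown sits. Compound 4, `CCCOc1nc(N)c2nc(O)n(Cc3ccccc3)c2n1`, has not yet been measured. It differs from compound 1 in one place: propoxy in place of butyl on an aromatic carbon. For the measured compounds named here, no measured pair shows what this exchange does, so the size of the step in this assay is open; a modest rise in the number is expected. Compound 4 is estimated at 0.1 uM, with a range from 0.01 uM to 1 uM, an expected step of a 3.3-fold higher number from compound 1 to compound 4 (0.52 log units; beyond the scatter).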

Compound 4, minimum effective concentration: 0.01 uM
Compound 4: the middle estimate sits 10-fold (1.00 log units) above what was measured, and the stated range covers the measured number.
By their numbers in this assay, from the lowest: compound 4; then compound 1; then compound 3.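

In this assay, the aromatic carbon between two ring nitrogen atoms accepts propoxy in place of butyl without loss: the exchange gives a 3.0-fold lower number from compound 1 to compound 4 (0.48 log units; beyond the scatter) in this single pair. For the compounds shown here, the earlier compounds offered no pair that changed at this place, so this is the first direct reading of it. No measured property here explains the step. Still open, from the compounds shown here alone, is how an amine or a longer chain such as butoxy would fare at this place. Also open, going by these compounds, is whether propoxy would give a similar step with other groups elsewhere on the shared core.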